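Lengthening the amide nitrogen chain of compound 1 toward a phenyl

This account rests on a few compounds, and the source may have more. Where it says the series, first, only, none or still open, it means among the compounds named here.

For the measured compounds named here, compound 1 `CC(C)CCN1Cc2ccc(C(=O)N(C)CCC3CCNCC3)cc2CC(CC(=O)O)C1=O` is one of three compounds measured in a functional assay (plasma) for inhibition, with Homo sapiens as the target (a higher number here means a weaker inhibitor, a lower number a stronger inhibitor), where compound 1 gives 32 nM. It stands second highest of the three numbers: compound 3 `CCCCN1Cc2ccc(C(=O)N(C)CCC3CCNCC3)cc2CC(CC(=O)O)C1=O` gives 31 nM, and the step of a 1.0-fold lower number from compound 1 to compound 3 (0.01 log units; within the scatter) lies within the scatter, while compound 2 `CN(CCC1CCNCC1)C(=O)c1ccc2c(c1)CC(CC(=O)O)C(=O)NC2` gives 71 nM, and the step of a 2.2-fold higher number from compound 1 to compound 2 (0.35 log units; beyond the scatter) is a modest one. Read the other way, the step of a 2.3-fold lower number from compound 2 to compound 3 (0.36 log units; beyond the scatter) shows that a hydrogen on the amide-type nitrogen in the ring is the only change among these three that moves the number beyond the scatter.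

Compound 4 `CN(CCC1CCNCC1)C(=O)c1ccc2c(c1)CC(CC(=O)O)C(=O)N(CCCCCc1ccccc1)C2` is not yet measured. It differs from compound 1 by 3-phenylpropyl in place of isopropyl on a saturated chain carbon, two bonds along the chain from an amide-type nitrogen in a ring; cut one bond further out, this is isopentyl to 5-phenylpentyl. Both compound 1 and compound 4 keep the nitrogen substituted, so the step that bears most closely is the one within the scatter, a 1.0-fold lower number from compound 1 to compound 3 (0.01 log units; within the scatter). Going by the values given here, no measured step covers a phenyl at the end of this chain, so no direction can be drawn from the data. Compound 4 is therefore expected to give about 30 nM, between 12 nM and 75 nM, a step of a 1.1-fold lower number from compound 1 to compound 4 (0.03 log units; within the scatter).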

Compound 4, half-maximal inhibitory concentration: 8 nM
The estimate for compound 4 lay 3.8-fold (0.57 log units) above the measured number, outside the stated range (below it).
By their numbers in this assay, from the lowest: compound 4; then compounds 3 and 1 (each within the scatter of the next); then compound 2.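

Compounds 1 and 3 had suggested that the exact shape of the alkyl chain on the amide-type nitrogen in the ring hardly matters, but compound 4 shows that the outer end of this chain can still move the number: 3-phenylpropyl in place of isopropyl gives a 4.0-fold lower number from compound 1 to compound 4 (0.60 log units; beyond the scatter), and benzyl in place of hydrogen, four bonds along the chain from that nitrogen, gives a 3.9-fold lower number from compound 3 to compound 4 (0.59 log units; beyond the scatter). Measured from the unsubstituted nitrogen, 5-phenylpentyl gives an 8.9-fold lower number from compound 2 to compound 4 (0.95 log units; beyond the scatter), a larger step than butyl gives in a 2.3-fold lower number from compound 2 to compound 3 (0.36 log units; beyond the scatter). Nothing available explains why the number falls with this change.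

Compound 4 changes chain length and adds the phenyl together, so the two cannot be separated here. A plain pentyl chain, or a benzyl group directly on that nitrogen, would bear on this question.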